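Ring swap on the sulfonamide: difluorophenyl to dimethylphenyl

The source may report more compounds than this note shows. Statements on the series, on what has been measured and on what is new or still open speak of the compounds shown alone.

Compound 1, `CCCCOc1ccc(NS(=O)(=O)c2ccc(N3CCNC3=O)cc2)cc1`, gives 630 nM in a functional assay on HT-29 cells (Homo sapiens) for antiproliferative activity, read by sulforhodamine B assay, with a stated time of 48 h; on this read-out higher numbers stand for weaker inhibition and lower numbers for stronger inhibition.
Compound 2, `O=C1NCCN1c1ccc(S(=O)(=O)Nc2ccc(F)c(F)c2)cc1`, gives 350 nM in this assay.
Compound 3, `CC(C)(C)c1ccc(NS(=O)(=O)c2ccc(N3CCNC3=O)cc2)cc1`, reaches only the assay limit of > 1000 nM in this assay, not a number.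

Compound 2 has the lowest of the two numbers in this assay, yet its gap to compound 1 is within the scatter, so neither is called stronger. For the measured compounds named here, the one measured step, an at least 1.5-fold higher number from compound 1 to compound 3 (0.20 log units; that floor lies within the scatter), ends at the limit (the limit of > 1000 nM in this assay, at which 1 of the 3 values shown sits). Compound 4, `Cc1ccc(NS(=O)(=O)c2ccc(N3CCNC3=O)cc2)cc1C`, is unmeasured; it differs from compound 2 by 3,4-dimethylphenyl in place of 3,4-difluorophenyl on a sulfonamide nitrogen. Going by the values given here, no measured step touches this ring, so the step of an at least 1.5-fold higher number from compound 1 to compound 3 (0.20 log units; that floor lies within the scatter) bears only loosely on it. A modestly weaker result is expected, a 2.0-fold higher number from compound 2 to compound 4 (0.30 log units; within the scatter), with a fair chance of a limit. Compound 4 is estimated at 700 nM, between 250 nM and 2500 nM.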

Compound 4, half-maximal inhibitory concentration: 230 nM
Estimate against measurement, compound 4: 3.0-fold (0.48 log units) above, and the stated range ends above it.
By their numbers in this assay, from the lowest: compounds 4, 2 and 1 (each within the scatter of the next, the first and the last beyond it). At a limit, above all of these: compound 3.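

In this assay the swap to 3,4-dimethylphenyl gives a 1.5-fold lower number from compound 2 to compound 4 (0.18 log units; within the scatter) and so leaves compound 2 and compound 4 impossible to tell apart. On this sulfonamide nitrogen, then, the fluorine atoms of 3,4-difluorophenyl are not needed for a value in this range, since a ring bearing only carbon substituents serves as well. Nothing shown here accounts for this result.

Going by these compounds, what an amine or a carboxylic acid on this ring would give remains open. So does the effect of a ring carrying only one methyl group.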